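Swapping the Double Bonds of Compound 3

The source may hold more compounds than are shown below. What is called first, only, known or untested is meant among the compounds shown, and "the series" means these compounds.

In a functional assay on OVCAR-3 cells (Homo sapiens) for antiproliferative activity, read by WST assay, with a stated time of 72 h, in the presence of a further agent that is not named here (a lower number here means a stronger inhibitor, a higher number a weaker inhibitor), compound 1 (`CCCCCCCC/C=C\c1c(C)c(/C=C\CCCCCCCC)c2[n+](c1C)CCC2`) gives 860 nM while compound 2 (`CCCCCCCC/C=C/c1c(C)c(/C=C/CCCCCCCC)c2[n+](c1C)CCC2`) gives 700 nM and compound 3 (`CCCCCCCC/C=C\c1c(C)c(/C=C/CCCCCCCC)c(C)[n+]2c1CCC2`) gives 600 nM as its result, which places compound 3 within the scatter of both others. Moving to compound 4 (`CCCCCCCC/C=C\c1c(C)c(/C=C/CCCCCCCC)c2[n+](c1C)CCC2`) changes only the configuration as drawn (the two compounds have the same atoms and bonds and differ only in configuration as drawn: 2 of 2 stereo elements differ; a double bond is drawn E in compound 3 and Z in compound 4; a double bond is drawn Z in compound 3 and E in compound 4) so nothing leaves and nothing enters. Three measured steps of this same kind bear on it: a 1.2-fold lower number from compound 1 to compound 2 (0.09 log units; within the scatter) and a 1.4-fold lower number from compound 1 to compound 3 (0.16 log units; within the scatter) and a 1.2-fold lower number from compound 2 to compound 3 (0.07 log units; within the scatter) all stay within the scatter. No step beyond the scatter is therefore expected in this assay for this change. The expected step is a 1.2-fold higher number from compound 3 to compound 4 (0.07 log units; within the scatter) and has no clear direction. Compound 4 is estimated at 700 nM with an expected range from 350 nM to 1300 nM in this assay once measured.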

Compound 4, half-maximal inhibitory concentration: 500 nM
Beside the measured number, compound 4's estimate is 1.4-fold (0.15 log units) above it; measured number inside the range.
By their numbers in this assay, from the lowest: compounds 4, 3, 2 and 1 (each within the scatter of the next).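

Swapping which double bond is drawn Z and which is drawn E does not separate two compounds in this assay, giving a 1.2-fold lower number from compound 3 to compound 4 (0.08 log units; within the scatter). The other new steps agree: a 1.4-fold lower number from compound 2 to compound 4 (0.15 log units; within the scatter) and a 1.7-fold lower number from compound 1 to compound 4 (0.24 log units; within the scatter). Among these compounds, the four compounds now cover both double bonds Z, both E and each of the two mixed arrangements, and no pair among them differs beyond the scatter.

Among the compounds shown here, all four carry the same chains, so configuration is the only change tested here. On these data alone, whether a longer chain, or an amine or carboxylic acid in place of a chain, would move the number beyond the scatter remains open.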